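Terminal aryl variation in a succinate receptor antagonist series

The source may hold more compounds than are shown below. What is called first, only, known or untested is meant among the compounds shown, and "the series" means these compounds.

Measured so far:
compound 1, `O=C(CCCc1ccc2cccnc2n1)NCc1ccc(-c2ccc(F)c(Cl)c2)cc1`, 38 nM
compound 2, `CCc1cccc(-c2ccc(CNC(=O)CCCc3ccc4cccnc4n3)cc2)c1`, 65 nM

Among the compounds with values here, compound 2 holds the higher of the two numbers in a functional assay on CHO-K1 cells for antagonist activity at succinate receptor 1 (Homo sapiens), read by FLIPR and calcium flux (a higher number here means a weaker inhibitor, a lower number a stronger inhibitor), but its only neighbour is compound 1 and the step of a 1.7-fold higher number from compound 1 to compound 2 (0.23 log units; within the scatter) lies within the scatter, so the two compounds cannot be ordered on these data.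

Compound 3, `Cc1cc(-c2ccc(CNC(=O)CCCc3ccc4cccnc4n3)cc2)ccc1Cl`, has not been measured. The change from compound 2 is 4-chloro-3-methylphenyl in place of 3-ethylphenyl on an aromatic carbon. Within the data shown here, the one measured step that bears on it, a 1.7-fold higher number from compound 1 to compound 2 (0.23 log units; within the scatter), exchanged a halogenated terminal ring for an alkylated one without leaving the scatter. The change to compound 3 brings a chlorine back onto the terminal ring while keeping a small alkyl group, so no step beyond the scatter is expected; if anything, a drift back toward the number of compound 1 seems plausible.

Compound 3 is therefore expected to give about 48 nM in this assay, with a range of 22 nM to 105 nM, corresponding to an estimated step of a 1.4-fold lower number from compound 2 to compound 3 (0.13 log units; within the scatter).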

Compound 3, half-maximal inhibitory concentration: 300 nM
For compound 3 the middle estimate is 6.3-fold (0.80 log units) below the measured one; the measured number lies above the stated range.
By their numbers in this assay, from the lowest: compounds 1 and 2 (each within the scatter of the next); then compound 3.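

With 4-chloro-3-methylphenyl on the aromatic carbon para to a large group, this assay gives a 4.6-fold higher number from compound 2 to compound 3 (0.66 log units; beyond the scatter) and also a 7.9-fold higher number from compound 1 to compound 3 (0.90 log units; beyond the scatter) as its second step, so this position does respond to the choice of terminal ring, which the first pair could not show. A chlorine on the ring and a small alkyl group on the ring each occur in a compound at the low end of the series, yet together in compound 3 they do not hold the number there, so the kind of substituent alone does not predict the result across these three compounds. No measurement shown here explains the rise.

From the compounds shown here alone, it remains open which group of compound 3 carries the loss, and 4-chlorophenyl and 3-methylphenyl would separate the two. Also open, going by these compounds, is how this position takes a terminal ring bearing a methoxy group, a nitrile or an amine.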